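The compounds below may be only part of what the source reports. "The series", "measured", "known", "first", "only" and "open" are said of these compounds alone.

Measured compounds in a functional assay on the whole organism for inhibition, with Rattus norvegicus as the target, at a dose of 25 mg/kg by the intraperitoneal route; on this read-out higher numbers stand for more inhibition at the one dose given (going by the name of the read-out) and lower numbers for less inhibition:
- compound 1 `CN(C)c1ncnc2c1ncn2Cc1ccc(C#N)cc1` gives 0%
- compound 2 `Cc1cccc(Cn2cnc3c(N(C)C)ncnc32)c1` gives 12%
- compound 3 `CC(C)N(C)c1ncnc2c1ncn2CC1CC1` gives 32%

Compound 3 stands highest of the three numbers on this read-out. Its nearest neighbour is compound 2, whose value lies lower by a margin beyond the scatter, and compound 1 lies further below still, also beyond the scatter. For the measured compounds named here, no pair among the three differs in only one place, so none of these gaps can be tied to a single structural change; they show only that the two benzyl-type compounds sit below the cyclopropylmethyl compound 3.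

The next compound, compound 4 `c1nc(NCC2CC2)c2ncn(CC3CC3)c2n1`, is not yet measured. It differs from compound 3 by (cyclopropylmethyl)amino in place of isopropyl(methyl)amino on an aromatic carbon, at the place on the six-membered aromatic ring described for that change, next to the ring nitrogen. The count of heavy atoms is unchanged; one hydrogen-bond donor enters.

Going by the values given here, no measured pair shows what a change of this kind does in this assay, so the expected step rests on compound 3 alone. A small downward movement is expected, roughly within or just at the scatter, a number 7 percentage points lower from compound 3 to compound 4 (within the scatter). Compound 4 is accordingly estimated at 25%, in a range from 5% to 50%.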

Compound 4, a percentage reported as inhibition, in the whole organism at one dose (the size of the read-out at that dose, not a potency): 28%
The estimate for compound 4 lay 3 percentage points below the measured number, and the stated range covers the measured number.
By their numbers in this assay, from the lowest: compound 1; then compound 2; then compounds 4 and 3 (each within the scatter of the next).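

In this assay, for the compounds shown here, the first comparison that differs in one place gives a number 4 percentage points lower from compound 3 to compound 4 (within the scatter), so exchanging isopropyl(methyl)amino for (cyclopropylmethyl)amino on this aromatic carbon, next to the ring nitrogen, produces no change that can be read beyond the usual scatter. Going by these compounds alone, the exchange keeps the count at 5 heavy atoms but brings in a three-membered ring of carbon and 1 hydrogen-bond donor, and at the single dose of this read-out neither addition separates compound 4 from compound 3, although the result covers only this one pair of groups and says nothing about potency. No supporting data bear on why the two groups read alike.

On these data alone, whether a plain amino group, a morpholine ring or a longer chain such as n-hexylamino at this position would move the number beyond the scatter remains open. Within the data shown here, also open is what a change at the other substituted place would do, for example a 2-hydroxyethyl chain in place of the cyclopropylmethyl group of compound 4, since no step involving compound 1 or compound 2 can be read.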